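Thiophene in place of chlorophenyl on the aryl arm

The source may hold more compounds than are shown below. What is called first, only, known or untested is meant among the compounds shown, and "the series" means these compounds.

Compound 2 `Clc1ccc(-c2cn3ccnc3c(-c3ccc4ncn(C5CCCCC5)c4c3)n2)cc1` gives 11.6% in a functional assay on A549 cells (Homo sapiens) for inhibition, read by sulforhodamine B assay, with a stated time of 48 h, tested at 10 uM; a lower number here means less inhibition, a higher number more inhibition at the concentration tested (going by the name of the read-out). Of the three measured compounds it stands second highest: compound 3 `Brc1ccc(-c2cn3ccnc3c(-c3ccc4ncn(C5CCCCC5)c4c3)n2)cc1` gives 15.3%, and the step of a number 3.7 percentage points higher from compound 2 to compound 3 (within the scatter) lies within the scatter, while compound 1 `c1cn2cc(-c3ccsc3)nc(-c3ccc4ncn(C5CCCCC5)c4c3)c2n1` gives 3.97%, the step of a number 7.6 percentage points higher from compound 1 to compound 2 (within the scatter) likewise within the scatter. Compound 4 `c1csc(-c2cn3ccnc3c(-c3ccc4ncn(C5CCCCC5)c4c3)n2)c1` is not yet measured. It differs from compound 2 by thiophen-2-yl in place of 4-chlorophenyl on an aromatic carbon. Going by the values given here, the one measured step that bears on this is the reverse exchange, where the thiophen-3-yl of compound 1 gives way to the 4-chlorophenyl of compound 2 at a number 7.6 percentage points higher from compound 1 to compound 2 (within the scatter). Among the compounds with values here, compound 4 carries thiophen-2-yl rather than thiophen-3-yl, and no measured pair covers that difference. Putting a thiophene back in place of the halophenyl is therefore expected to move the number toward that of compound 1, but not beyond the scatter. The expected step is a number 6.6 percentage points lower from compound 2 to compound 4 (within the scatter). Compound 4 is estimated at 5%, with a range from 0% to 15%.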

Compound 4, a percentage reported as inhibition, at one concentration (the size of the read-out at that concentration, not a potency): 5.33%
Compound 4: the middle estimate sits 0.3 percentage points below what was measured; low and high end bracket the measured number.
By their numbers in this assay, from the lowest: compounds 1, 4, 2 and 3 (each within the scatter of the next, the first and the last beyond it).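

The thiophen-2-yl and thiophen-3-yl groups cannot be told apart at this position, with a number 1.4 percentage points higher from compound 1 to compound 4 (within the scatter). Thiophen-2-yl also stays within the scatter of both halophenyl compounds, at a number 6.3 percentage points lower from compound 2 to compound 4 (within the scatter) and a number 10 percentage points lower from compound 3 to compound 4 (within the scatter), whereas thiophen-3-yl is separated from 4-bromophenyl, at a number 11.3 percentage points higher from compound 1 to compound 3 (beyond the scatter); the thiophene and halophenyl groups therefore do not fall into two clearly separate classes across these four compounds. Nothing available here bears on what lies behind these numbers.

As far as these compounds go, every group tested at this position is a single aromatic ring, so it remains open whether an amine, a carboxylic acid or a longer alkyl chain there would give a number clear of this cluster. These readings at one concentration also leave the potency of all four compounds open.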